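This account rests on a few compounds, and the source may have more. Where it says the series, first, only, none or still open, it means among the compounds named here.

In a functional assay on HOS-TE85 cells (Homo sapiens) for inhibition, read by CCK-8 assay, with a stated time of 72 h (a lower number here means a stronger inhibitor, a higher number a weaker inhibitor), compound 1 `COc1ccccc1N1C(=O)CSC1c1cccc(C(=O)NCCCCn2cncn2)c1` gives > 1000 nM, which is a limit and not a number. Compound 2 `O=C(NCCCCn1cccn1)c1cccc(C2SCC(=O)N2c2cccnc2)c1` gives > 1000 nM in this assay, and this too is only a limit. The measured picture therefore comes down to a single line: the limit of > 1000 nM in this assay, at which 2 of the 2 values shown sit. Within the data shown here, neither compound has an exact value, and no step between measured compounds is available for comparison.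

Compound 3 `COc1ccccc1N1C(=O)CSC1c1cccc(C(=O)NCCCCn2cccn2)c1` differs from compound 2 in one place: 2-methoxyphenyl in place of pyridin-3-yl on an amide-type nitrogen in a ring. A 2-methoxyphenyl group stands in place of pyridin-3-yl on an amide-type nitrogen in a ring. Among the measured compounds shown here, with no measured step to scale this swap against, no step beyond the scatter is expected in this assay, and no direction can be favoured. This expectation rests on compound 2, whose > 1000 nM is a limit. Another limit is the likeliest report for compound 3, though a number close to that limit remains possible. Put as a number, the expected step is a step that the limit leaves unreadable from compound 2 to compound 3. For compound 3 the estimated value is 1500 nM, with an expected range from 500 nM to 5000 nM.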

Compound 3, half-maximal inhibitory concentration: 91.7 nM
Compound 3: middle estimate off by 16-fold (1.21 log units), on the high side, outside the stated range (below it).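

In this assay, putting 2-methoxyphenyl in place of pyridin-3-yl on the amide-type nitrogen in the ring gives an at least 10-fold lower number from compound 2 to compound 3 (1.03 log units; beyond the scatter), so the group at this position can decide whether a measurable value appears at all. The far end of the molecule matters as well: 1H-pyrazol-1-yl in place of 1H-1,2,4-triazol-1-yl on the saturated chain carbon, four bonds along the chain from an amide-type nitrogen, gives an at least 10-fold lower number from compound 1 to compound 3 (1.03 log units; beyond the scatter). Compound 3 carries both 2-methoxyphenyl and 1H-pyrazol-1-yl, and undoing either single change leads to a compound reported only as a limit: the limit of > 1000 nM in this assay, at which 2 of the 3 values shown sit.

As far as these compounds go, compound 1 and compound 2 have limits rather than exact values, so the full size of each step remains unknown, as does whether the two groups act independently or depend on each other. A plain phenyl on the ring nitrogen would help show what the methoxy group adds, while an imidazole or an amine at the end of the chain would test how much this activity depends on the pyrazole.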